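A Trifluoromethylphenyl Variant of Compound 1

The source may report more compounds than this note shows. Statements on the series, on what has been measured and on what is new or still open speak of the compounds shown alone.

Three compounds have been measured in a functional assay on MCF7 cells (Homo sapiens) for inhibition, read by MTT assay, with a stated time of 24 h; a higher number here means a weaker inhibitor, a lower number a stronger inhibitor:

compound 1 `O=C(O)C1=Cc2ccccc2OC1(OCc1cc(-c2ccc(F)cc2)no1)C(F)(F)F` — 64200 nM
compound 2 `CCOC(=O)C1=Cc2ccccc2OC1(OCc1cn(CC(=O)Nc2cccc(Cl)c2)nn1)C(F)(F)F` — 11600 nM
compound 3 `CCOC(=O)C1=Cc2ccccc2OC1(OCc1cc(-c2ccc(F)cc2)no1)C(F)(F)F` — 48200 nM

Compound 1 stands highest of these three numbers. Its nearest neighbour is compound 3, with a 1.3-fold lower number from compound 1 to compound 3 (0.12 log units; within the scatter); the change there is ethyl in place of hydrogen on an oxygen next to a carbonyl group. Furthest from it is compound 2, which differs from compound 1 in more than one place, so the two values alone show the gap and no single step can be drawn from it.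

Compound 4 `O=C(O)C1=Cc2ccccc2OC1(OCc1cc(-c2cccc(C(F)(F)F)c2)no1)C(F)(F)F` differs from compound 1 by 3-(trifluoromethyl)phenyl in place of 4-fluorophenyl on an aromatic carbon. Among the compounds with values here, no measured step touches this aryl group: the only single-point step runs between the acid and its ethyl ester and lies within the scatter, and compound 2 carries a different five-membered ring altogether. With nothing to guide the direction, compound 4 is expected to stay close to compound 1, with a step of a 1.3-fold lower number from compound 1 to compound 4 (0.11 log units; within the scatter) that need not exceed the scatter. Compound 4 is therefore estimated at 50000 nM in this assay, within a range from 15000 nM to 160000 nM.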

Compound 4, half-maximal inhibitory concentration: > 150000 nM
Compound 4: only a limit was reported; the forecaster's own chance of this, stated with the estimate: 20%; middle value at least 3.0-fold (0.47 log units) away from the limit.
By their numbers in this assay, from the lowest: compound 2; then compounds 3 and 1 (each within the scatter of the next). At a limit, above all of these: compound 4.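

In this assay compound 4 gave only a limit, not a number: the limit of > 150000 nM in this assay, at which 1 of the 4 values shown sits. Within the data shown here, the aromatic carbon next to the ring nitrogen now shows a change beyond the scatter, an at least 2.3-fold higher number from compound 1 to compound 4 (0.36 log units; beyond the scatter), with 3-(trifluoromethyl)phenyl in place of 4-fluorophenyl, whereas the only earlier single-place step, a 1.3-fold lower number from compound 1 to compound 3 (0.12 log units; within the scatter), stayed within it. From the compounds shown here alone, this aryl group is therefore the first place where a single change is seen to move the result, towards a weaker inhibitor, and how far it moves remains unknown past the limit.

What a plain phenyl, 3-fluorophenyl or 4-(trifluoromethyl)phenyl would give here remains open, so the compounds shown do not separate the choice of substituent from its place on the phenyl ring. Also open, going by these compounds, is how the ethyl ester of compound 4 would compare with compound 3.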